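A few compounds are considered here, and "the series" means these few. Any claim that something is new, unique, unknown or untested is made for them only; others in the source may bear on it.

In a functional assay for inhibition, with Homo sapiens as the target (on this read-out lower numbers stand for stronger inhibition and higher numbers for weaker inhibition), compound 3 `CC(C)c1ccc2oc(NC(CC3CCCCC3)c3ccccc3)nc2c1` gives 6 nM. That places it within the scatter of compound 2 `Cc1ccc2oc(NC(CC3CCCCC3)c3ccccn3)nc2c1`, which gives 4 nM. Compound 1 `COc1ccc(C(CC2CCCCC2)Nc2nc3ccccc3o2)cc1` stands well apart at 550 nM, a number beyond the scatter higher than that of compound 3, and so a clearly weaker inhibitor. Among the measured compounds shown here, these three compounds differ in more than one place, so no measured pair isolates a single change.

The next compound, compound 4 `CS(=O)(=O)Nc1ccc2oc(NC(CC3CCCCC3)c3ccccc3)nc2c1`, keeps the rest of compound 3 and carries methanesulfonamido in place of isopropyl on an aromatic carbon, (methanesulfonamido in place of isopropyl on an aromatic carbon). The group sits on the six-membered aromatic ring of carbon only, part of a fused system of two rings.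

For the measured compounds named here, no measured compound carries methanesulfonamido, so the expectation rests on little. The low number of compound 3, 6 nM, comes with a substituent made of carbon only, and the entering group is larger and contains nitrogen, oxygen and sulfur. A move towards weaker inhibition therefore seems more likely than no change. In this assay the expected step is a 6.7-fold higher number from compound 3 to compound 4 (0.82 log units; beyond the scatter), estimated to lie beyond the scatter, though with wide uncertainty. Compound 4 is estimated at 40 nM, with an expected range from 8 nM to 250 nM.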

Compound 4, half-maximal inhibitory concentration: 160 nM
Compound 4: the middle estimate sits 4.0-fold (0.60 log units) below what was measured; measured number inside the range.
By their numbers in this assay, from the lowest: compounds 2 and 3 (each within the scatter of the next); then compound 4; then compound 1.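

Replacing isopropyl with methanesulfonamido on this aromatic carbon gives a 27-fold higher number from compound 3 to compound 4 (1.43 log units; beyond the scatter) in this assay. Among the compounds shown here, this is the first single change that can be read, and it shows that the number depends strongly on the group at this place, on the six-membered aromatic ring of carbon only, when the rest of compound 3 is held fixed. The earlier compounds differed in more than one place and could not show this, and nothing given here explains why this exchange has so large an effect.

For the compounds shown here, with only one group compared against isopropyl, it remains open whether an amine, an acetamido group or a methylsulfonyl group at this place would give a number closer to that of compound 3 or to that of compound 4, and so which part of methanesulfonamido goes with the step. Going by these compounds, it is also open whether methanesulfonamido would give a step of similar size on the rest of compound 2, which differs from compound 3 in more than one place.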